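Phenyl replaces dichlorophenyl on the triazole: expected inhibition

The source may hold more compounds than are shown below. What is called first, only, known or untested is meant among the compounds shown, and "the series" means these compounds.

Measured so far in an assay on Sf9 cells for inhibition of protein deacetylase HDAC6 (Homo sapiens), read by fluorescence, with a stated time of 40 min, tested at 100 nM; on this read-out lower numbers stand for less inhibition and higher numbers for more inhibition at the one concentration tested (going by the name of the read-out):
compound 1 `O=C(NO)c1ccc(NCc2nc(-c3ccc(F)cc3)nn2-c2ccccc2)cc1`, 70.9%
compound 2 `CCc1ccc(-c2nc(CNc3ccc(C(=O)NO)cc3)n(-c3ccccc3)n2)cc1`, 54.6%
compound 3 `O=C(NO)c1ccc(NCc2nc(-c3ccc(Cl)c(Cl)c3)nn2-c2ccccc2)cc1`, 34.5%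

Compound 3 stands lowest of the three numbers; the nearest is compound 2 (a number 20.1 percentage points lower from compound 2 to compound 3 (beyond the scatter)), the furthest compound 1 (a number 36.4 percentage points lower from compound 1 to compound 3 (beyond the scatter)). Compound 4 `O=C(NO)c1ccc(NCc2nc(-c3ccccc3)nn2-c2ccccc2)cc1` is not yet measured. It differs from compound 3 thus: phenyl in place of 3,4-dichlorophenyl on an aromatic carbon. The two steps into compound 3 bear on this change, since both put a substituted phenyl in place of the 3,4-dichlorophenyl; both were beyond the scatter, one modest and one large. Removing both chlorines is therefore expected to lift the number, by a step of roughly a number 25.5 percentage points higher from compound 3 to compound 4 (beyond the scatter). For compound 4 the estimate is 60%, with a range from 40% to 80%.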

Compound 4, a percentage reported as inhibition, at one concentration (the size of the read-out at that concentration, not a potency): 72.6%
Estimate against measurement, compound 4: 12.6 percentage points below; measured number inside the range.
By their numbers in this assay, from the lowest: compound 3; then compound 2; then compounds 1 and 4 (each within the scatter of the next).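

In this assay, the plain phenyl at this position stands well clear of 3,4-dichlorophenyl (a number 38.1 percentage points higher from compound 3 to compound 4 (beyond the scatter)). Hydrogen in place of ethyl also lifts the number (a number 18 percentage points higher from compound 2 to compound 4 (beyond the scatter)), while hydrogen in place of fluoro gives only a small shift (a number 1.7 percentage points higher from compound 1 to compound 4 (within the scatter)), so among these compounds fluoro costs nothing measurable, whereas ethyl and the two chlorines each cost inhibition. Nothing available accounts for these differences.

Still open, as far as these compounds go, is how a single chlorine compares with the pair in 3,4-dichlorophenyl. Also open, from the compounds shown here alone, is how an amine, a methoxy group or a carboxylic acid on this phenyl would read.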